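A few compounds are considered here, and "the series" means these few. Any claim that something is new, unique, unknown or untested is made for them only; others in the source may bear on it.

Measured in a functional assay on MGC-803 cells (Homo sapiens) for antiproliferative activity, read by MTT assay, with a stated time of 48 h; a lower number here means that less compound is needed, a higher number that more compound is needed for the effect:
Compound 1 `CC1=NN(S(=O)(=O)c2ccccc2C)C(c2cc(Br)ccc2O)C1`: > 60000 nM (a limit)
Compound 2 `COc1ccc(S(=O)(=O)N2N=C(C)CC2c2cc(Br)ccc2O)cc1`: 20300 nM

Going by the values given here, compound 2, at 20300 nM, holds the only actual number in this assay. The result for compound 1 is only a limit, > 60000 nM.

Compound 3 `CC1=NN(S(=O)(=O)c2ccccc2I)C(c2cc(Br)ccc2O)C1` carries 2-iodophenyl in place of the 4-methoxyphenyl of compound 2 on a sulfonyl sulfur: 2-iodophenyl in place of 4-methoxyphenyl on a sulfonyl sulfur. Among the compounds with values here, one measured step bears on this change, and it ran the other way. Putting 4-methoxyphenyl in place of 2-methylphenyl gave an at least 2.9-fold lower number from compound 1 to compound 2 (0.47 log units; beyond the scatter). Compound 3 gives up that 4-methoxyphenyl for a group named much like the 2-methylphenyl of compound 1, so a higher number is expected in this assay, possibly only a limit. The expected change is a 2.2-fold higher number from compound 2 to compound 3 (0.35 log units; beyond the scatter). Compound 3 is estimated at 45000 nM, with an expected range of 18000 nM to 100000 nM.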

Compound 3, half-maximal effective concentration: 52500 nM
For compound 3 the middle estimate is 1.2-fold (0.07 log units) below the measured one; the range from low to high includes it.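

In this assay, this position on the sulfonyl sulfur now has a change sized by two actual numbers, and 2-iodophenyl in place of 4-methoxyphenyl gives a 2.6-fold higher number from compound 2 to compound 3 (0.41 log units; beyond the scatter), so both groups with a substituent named at the 2-position stand on the higher side of 4-methoxyphenyl. Iodo in place of methyl on an aromatic carbon gives an at least 1.1-fold lower number from compound 1 to compound 3 (0.05 log units; that floor lies within the scatter), so this pair sets no firm order. The result for compound 1 is a limit, not a number: the limit of > 60000 nM in this assay, at which 1 of the 3 values shown sits.

From the compounds shown here alone, what stays open is whether the lower number belongs to the methoxy group itself or to its place on the ring, which 2-methoxyphenyl or 4-iodophenyl on the sulfonyl sulfur would separate. Going by these compounds, how an amine or a carboxylic acid on this phenyl ring would read in this assay also stays open.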